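Acetyl for cyclopropyloxy on an imidazoline phenyl ether

The source may hold more compounds than are shown below. What is called first, only, known or untested is meant among the compounds shown, and "the series" means these compounds.

Measured so far:
compound 1 `CC(Oc1ccccc1OC1CC1)C1=NCCN1` — 676 nM
compound 2 `C=CCc1cccc(CC=C)c1OC(C)C1=NCCN1` — 129 nM

In an assay on CHO cells for displacement of a labelled ligand from Alpha-2C adrenergic receptor (Homo sapiens) (on this read-out higher numbers stand for weaker inhibition and lower numbers for stronger inhibition), compound 1 gives 676 nM, the highest of the two numbers recorded; compound 2 gives 129 nM, a number well below it, and the gap between the two lies beyond the scatter. Compound 3 `CC(=O)c1ccccc1OC(C)C1=NCCN1` has not been measured. It differs from compound 1 in one place: acetyl in place of cyclopropyloxy on an aromatic carbon. Among the measured compounds shown here, no pair of measured compounds shows this change, so its effect is not known from the data at hand. The acetyl keeps one hydrogen-bond acceptor in the same place on the ring and is smaller by one heavy atom, so the step is expected to be small, and the number for compound 3 is estimated to lie near that of compound 1: a step of a 1.5-fold lower number from compound 1 to compound 3 (0.18 log units; within the scatter), not clearly beyond the scatter. Compound 3 is expected to give 450 nM, in the range 120 nM to 1700 nM.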

Compound 3, inhibition constant: 7410 nM
The estimate for compound 3 lay 16-fold (1.22 log units) below the measured number, and the stated range ends below it.
By their numbers in this assay, from the lowest: compound 2; then compound 1; then compound 3.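

In this assay, among the compounds shown here, the aromatic carbon carrying cyclopropyloxy proves sensitive to substitution: exchanging that group for acetyl gives an 11-fold higher number from compound 1 to compound 3 (1.04 log units; beyond the scatter) and is the first single change at this position to be measured. The two groups have the same count of hydrogen-bond acceptors and differ by only one heavy atom, so these counts do not by themselves preserve the number seen for compound 1. Nothing measured here accounts for the step.

The compounds shown leave open whether the step follows the loss of the three-membered ring, the change from an ether oxygen to a carbonyl, or both. A methoxy group or an open-chain ethoxy group on this carbon could separate these possibilities, while an amine would show how a different kind of substituent is tolerated there.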